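Purine linker swap: sulfur to oxygen in the piperazine series

The source may hold more compounds than are shown below. What is called first, only, known or untested is meant among the compounds shown, and "the series" means these compounds.

Measured compounds:
compound 1, `OC(CSc1ncnc2[nH]cnc12)CN1CCN(C(c2ccc(F)cc2)c2ccc(F)cc2)CC1`, this assay 0.15 mg/kg
compound 2, `CC(=O)OC(CNc1[nH]cnc2ncnc1-2)CN1CCN(C(c2ccc(F)cc2)c2ccc(F)cc2)CC1`, this assay 0.27 mg/kg
compound 3, `OC(COc1[nH]cnc2ncnc1-2)CN1CCN(C(c2ccccc2)c2ccccc2)CC1`, this assay 0.9 mg/kg

The read-out is a functional assay on the whole organism with Canis familiaris (Canis lupus familiaris) as the target; a higher number here means that more compound is needed for the effect, a lower number that less compound is needed. Compound 1 stands at the lowest of the three numbers. Its nearest neighbour is compound 2, whose number is higher but within the scatter, so no order can be set between those two. Compound 3 sits furthest away, with a number higher than that of compound 1 by more than the scatter allows.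

Not yet measured is compound 4, `OC(COc1[nH]cnc2ncnc1-2)CN1CCN(C(c2ccc(F)cc2)c2ccc(F)cc2)CC1`. Relative to compound 1 the change is a group of 10 heavy atoms (5 carbon, 4 nitrogen, 1 oxygen; one five-membered aromatic ring with 2 hetero atoms, one six-membered aromatic ring with 2 hetero atoms) in place of a group of 10 heavy atoms (5 carbon, 4 nitrogen, 1 sulfur; one five-membered aromatic ring with 2 hetero atoms, one six-membered aromatic ring with 2 hetero atoms), on a saturated chain carbon, two bonds along the chain from an oxygen on a saturated carbon. For the measured compounds named here, no pair of measured compounds differs in just one place, so no single step can be read off directly. Compound 3 carries the same entering group as compound 4, but it also lacks the fluorines of the benzhydryl part, so its higher number cannot be attributed to the linker alone.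

Expectation: a small rise in the number from compound 1, at or just beyond the scatter, giving a 2.3-fold higher number from compound 1 to compound 4 (0.37 log units; beyond the scatter). Compound 4 is estimated at 0.35 mg/kg, with a range from 0.15 mg/kg to 0.9 mg/kg.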

Compound 4, dose for half-maximal effect: 0.72 mg/kg
Compound 4: middle estimate off by 2.1-fold (0.31 log units), on the low side, within the range that was stated.
By their numbers in this assay, from the lowest: compounds 1 and 2 (each within the scatter of the next); then compounds 4 and 3 (each within the scatter of the next).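

In this assay, the change at this place, on a saturated chain carbon, two bonds along the chain from an oxygen on a saturated carbon, can now be read alone: with the rest of the structure unchanged, the sulfur-containing group gives way to the oxygen-containing group (a 4.8-fold higher number from compound 1 to compound 4 (0.68 log units; beyond the scatter)). The step lies beyond the scatter, so the linking atom alone moves the dose needed for the effect, and more compound is needed with oxygen than with sulfur in this single pair. For the compounds shown here, the higher number of compound 3 can therefore no longer be set aside as a matter of the missing fluorines alone, although no step isolating those fluorines is available. No measurement at hand accounts for the step.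

Going by these compounds, whether a methylene link or a longer chain at this place would stay near compound 1 remains open. So does the effect of the nitrogen link with a free hydroxyl, as compound 2 also carries an acetyl ester.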